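The source may hold more compounds than are shown below. What is called first, only, known or untested is meant among the compounds shown, and "the series" means these compounds.

Compound 2 `C=C1[C@](C)(O)CC[C@@]1(C)c1ccc(C)cc1` is the parent of this pair. In a functional assay on HCT-8 cells (Homo sapiens) for cytotoxicity, read by MTT assay (on this read-out higher numbers stand for weaker inhibition and lower numbers for stronger inhibition), compound 2 gives only a limit, > 10 ug/mL. Compound 1 `C=C1[C@](C)(O)CC[C@@]1(C)c1ccc(C)c(O)c1` likewise gives only a limit in this assay, > 10 ug/mL. The step that the two limits leave unreadable from compound 1 to compound 2 cannot be read, since both values sit at the limit of > 10 ug/mL in this assay, at which 2 of the 2 values shown sit. Compound 3 `C=C1[C@](C)(O)CC[C@@]1(C)c1ccc(C)cc1O` differs from compound 2 by hydroxy in place of hydrogen on an aromatic carbon. Among the measured compounds shown here, the one measured step touches a hydroxy on the same ring but has no readable size, so no shift beyond the scatter is expected, and the step that the limit leaves unreadable from compound 2 to compound 3 is estimated. Compound 3 is expected to give 20 ug/mL, within 8 ug/mL to 60 ug/mL, most likely again as a limit.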

Compound 3, half-maximal inhibitory concentration: > 10 ug/mL
Compound 3: a limit, no number; the forecaster's own chance of this, stated with the estimate: 80%; the middle value lies beyond the limit too.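

In this assay compound 2 and compound 3 each give only a limit, so no step between them can be read: the limit of > 10 ug/mL in this assay, at which 3 of the 3 values shown sit.

Going by these compounds, whether hydroxy in place of hydrogen on an aromatic carbon changes the inhibition, and by how much, stays open.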